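Pyridin-3-yl amine in place of the fluorobenzamide

The source may hold more compounds than are shown below. What is called first, only, known or untested is meant among the compounds shown, and "the series" means these compounds.

Measured compounds:
- compound 1 `CC(=O)c1cc(C(=O)N[C@@H](C)Cn2ccc(-c3cc(F)c(C#N)c(Cl)c3)n2)n[nH]1`: in an ADME assay on PC-3 cells (Homo sapiens) for cytotoxicity, read by CCK-8 assay, with a stated time of 6 days (a lower number here means a stronger inhibitor, a higher number a weaker inhibitor), compound 1 gives > 30000 nM, a limit of the assay.
- compound 2 `C[C@@H](Cn1ccc(-c2ccc(C#N)c(Cl)c2)n1)NC(=O)c1cccc(OCC(O)CO)c1`: compound 2 gives > 30000 nM, again a limit of the assay.
- compound 3 `C[C@@H](Cn1ccc(-c2ccc(C#N)c(Cl)c2)n1)NC(=O)c1ccccc1F`: compound 3 gives > 30000 nM, also a limit of the assay.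

Compound 3 therefore stands where everything measured so far stands: at the limit, with no number of its own. Nothing separates compound 3 from compound 1 or compound 2 on what is shown; all three share (the limit of > 30000 nM in this assay, at which 3 of the 3 values shown sit), and no step between any pair can be drawn. Among the measured compounds shown here, the series so far reads as inactive in this assay down to that limit.

Compound 4 `C[C@@H](Cn1ccc(-c2ccc(C#N)c(Cl)c2)n1)Nc1cccnc1` keeps the shared core of compound 3 and changes one place: pyridin-3-yl in place of (2-fluorophenyl)carbonyl on an amine nitrogen. The amide link is thereby removed and the nitrogen carries an aromatic ring directly.

For the measured compounds named here, with no measured step to lean on, and with every value at the limit (the limit of > 30000 nM in this assay, at which 3 of the 3 values shown sit), no step beyond the scatter is expected in this assay in either direction. Compound 4 is expected to give about 40000 nM, within 15000 nM to 120000 nM, most probably reported again only as a limit. The expected step from compound 3 to compound 4 is a step that the limit leaves unreadable from compound 3 to compound 4, which is none beyond the scatter.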

Compound 4, half-maximal inhibitory concentration: > 30000 nM
Compound 4 gave a limit, no number; the forecaster's own chance of this, stated with the estimate: 85%; the middle value is on the limit's open side.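

No step from compound 3 to compound 4 can be read in this assay, because both values are limits of the assay, not numbers: the limit of > 30000 nM in this assay, at which 4 of the 4 values shown sit.

The compounds shown leave open how any of them ranks in this assay and whether pyridin-3-yl in place of (2-fluorophenyl)carbonyl on the amine nitrogen changes the read-out at all.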